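The compounds below may be only part of what the source reports. "The series", "measured", "known", "first", "only" and "open" are said of these compounds alone.

In an ADME assay on HEK-293T cells (Homo sapiens) for cytotoxicity, read by CCK-8 assay, with a stated time of 48 h (on this read-out lower numbers stand for higher toxicity in this test and higher numbers for lower toxicity in this test), compound 1 (`O=C(CNc1nc(N2CCc3ccccc3C2)nc2ccccc12)Nc1ccc2ccccc2c1`) gives > 100000 nM as a limit of the assay and not a number. Compound 1 therefore stands at the limit of > 100000 nM in this assay, at which 2 of the 3 values shown sit, with no exact place of its own. The change to compound 4 (`O=C(CNc1nc(N2CCc3ccccc3C2)nc2ccccc12)Nc1ccccc1`) is phenyl in place of naphthalen-2-yl on an amide-type nitrogen and puts phenyl in place of naphthalen-2-yl on an amide-type nitrogen. Within the data shown here, one measured step touches this same place, with benzyl in place of naphthalen-2-yl, and it reads an at least 3.4-fold lower number from compound 1 to compound 2 (0.53 log units; beyond the scatter) and is beyond the scatter. In that step compound 2 (`O=C(CNc1nc(N2CCc3ccccc3C2)nc2ccccc12)NCc1ccccc1`) gives 29400 nM as a measured number. Compound 3 (`CCN(CC)c1nc(SCC(=O)Nc2ccccc2)c2ccccc2n1`) also has phenyl on an amide-type nitrogen, on a different core, and it gives > 100000 nM as a limit. Given the drop seen for compound 2 at 29400 nM, a smaller change than the benzyl step is expected, toward lower numbers. Compound 4 may well stay at the limit, as compound 3 does at > 100000 nM. The expected step is an at least 1.2-fold lower number from compound 1 to compound 4 (0.09 log units; that floor lies within the scatter) on this reading. Compound 4 is estimated at 80000 nM with an expected range from 30000 nM to 200000 nM in this assay once it is measured.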

Compound 4, half-maximal cytotoxic concentration: 36600 nM
For compound 4 the middle estimate is 2.2-fold (0.34 log units) above the measured one; the measured number falls inside the stated range.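

In this assay phenyl on the amide-type nitrogen also lowers the number, with an at least 2.7-fold lower number from compound 1 to compound 4 (0.43 log units; beyond the scatter), so the drop seen earlier is not confined to benzyl. Phenyl and benzyl cannot be told apart in this place, with a 1.2-fold higher number from compound 2 to compound 4 (0.10 log units; within the scatter), and of the three groups on the shared core only naphthalen-2-yl stands apart from the other two. The full size of both drops stays unknown, since the value of compound 1 is a limit of the assay and not a number: the limit of > 100000 nM in this assay, at which 2 of the 4 values shown sit.

The compounds shown leave open how a non-aromatic group such as cyclohexyl or a short chain such as methyl would read in this place. They also leave open whether a pyridine ring or a phenyl ring carrying a carboxylic acid would give a number like those of the phenyl and benzyl compounds.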